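One Fluorine Change Carried Across Two Related Cores

The source may hold more compounds than are shown below. What is called first, only, known or untested is meant among the compounds shown, and "the series" means these compounds.

The measured compounds and their values in a functional assay on HepG2 cells (Homo sapiens) for cytotoxicity, read by MTT assay, with a stated time of 48 h; a lower number here means a stronger inhibitor, a higher number a weaker inhibitor:
Compound 1 `COc1cccc2[nH]cc(C3(c4c[nH]c5cccc(OC)c45)C(=O)Nc4ccccc43)c12` gives 9000 nM.
Compound 2 `O=C1Nc2ccccc2C1(c1c[nH]c2ccc(Br)cc12)c1c[nH]c2ccc(Br)cc12` gives 15800 nM.
Compound 3 `COc1cccc2[nH]cc(C3(c4c[nH]c5cccc(OC)c45)C(=O)Nc4ccc(F)cc43)c12` gives 18000 nM.

Compound 1 and compound 3 share a core and differ in one place: fluoro in place of hydrogen on an aromatic carbon. That change gave a 2.0-fold higher number from compound 1 to compound 3 (0.30 log units; within the scatter), so the two numbers cannot be told apart with confidence. Compound 2 rests on a different core; the difference between the two cores is not broken down here. Its value in this assay sits close to those of compound 3 and compound 1, and all three lie within the usual scatter of one another, so none of them can be called stronger or weaker than the others.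

Compound 4 `O=C1Nc2ccc(F)cc2C1(c1c[nH]c2ccc(Br)cc12)c1c[nH]c2ccc(Br)cc12` is the unmeasured partner of compound 2. The change that leads to it is fluoro in place of hydrogen on an aromatic carbon, and its place is described in the same words as the place of the change from compound 1 to compound 3, so it is the same change made on the other core. Going by the values given here, with only one earlier example of this change, the expectation rests on that single step: compound 4 is expected to give 25000 nM in this assay, somewhere between 11000 nM and 55000 nM. Because the earlier step was a 2.0-fold higher number from compound 1 to compound 3 (0.30 log units; within the scatter), the step from compound 2 to compound 4 is estimated at a 1.6-fold higher number from compound 2 to compound 4 (0.20 log units; within the scatter), a change that would again fall within the scatter.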

Compound 4, half-maximal inhibitory concentration: 12800 nM
Compound 4: the middle estimate sits 2.0-fold (0.29 log units) above what was measured; the measured number falls inside the stated range.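

On the core of compound 2, in this assay, fluoro in place of hydrogen on an aromatic carbon gave a 1.2-fold lower number from compound 2 to compound 4 (0.09 log units; within the scatter), so the numbers for this pair cannot be told apart with confidence. Set beside the earlier step on the other core, the result gives no sign that the core alters what this change does: the same change on two cores in this assay, a 2.0-fold higher number (0.30 log units; within the scatter) from compound 1 to compound 3 and a 1.2-fold lower number (0.09 log units; within the scatter) from compound 2 to compound 4, 2.5-fold (0.39 log units) apart, within the scatter of two such steps. Going by these compounds alone, this does not prove that the change carries over unaltered, or even that it shifts the number at all, since there are only two pairs, each step lies within the scatter, and a small real difference between the cores could stay hidden in that scatter.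

The compounds shown leave open whether a different group on this same aromatic carbon, such as chloro, a nitrile, an amine or a carboxylic acid, would give a step large enough to read clearly on either core. They also leave open whether fluoro would behave in the same way on other aromatic carbons of these two cores, where a step beyond the scatter would make a comparison between the cores far more informative.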